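A Cyano Group Added to Compound 3

A few compounds are considered here, and "the series" means these few. Any claim that something is new, unique, unknown or untested is made for them only; others in the source may bear on it.

Three measured compounds share one core and differ in the group on an amine nitrogen: compound 1 (`COc1ccc(-c2c(C)nc3c(N4CC[C@@H](NC(=O)COc5ccccc5)C4)cc(C)nn23)cc1OC`), compound 2 (`COc1ccc(-c2c(C)nc3c(N4CC[C@@H](NS(=O)(=O)C(C)C)C4)cc(C)nn23)cc1OC`) and compound 3 (`COc1ccc(-c2c(C)nc3c(N4CC[C@@H](NS(=O)(=O)c5ccccc5)C4)cc(C)nn23)cc1OC`). In an ADME assay on microsomes from liver (Mus musculus) for metabolic stability, read by LC-MS, with NADPH named in the record, with a stated time of 60 min, tested at 1 uM, in the absence of a further agent (on this read-out higher numbers stand for a more stable compound and lower numbers for a less stable compound), compound 1 gives > 95% as a limit of the assay and not a number. Compound 2 gives > 95% as a limit too. Compound 3 also gives a limit of > 95% and so has no exact number.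

Compound 4 (`COc1ccc(-c2c(C)nc3c(N4CC[C@@H](NS(=O)(=O)c5ccc(C#N)cc5)C4)cc(C)nn23)cc1OC`) carries cyano in place of hydrogen on an aromatic carbon, turning phenylsulfonyl into (4-cyanophenyl)sulfonyl: cyano in place of hydrogen on an aromatic carbon.

The closest measured change is a step that the two limits leave unreadable from compound 2 to compound 3 with phenyl in place of isopropyl on a sulfonyl sulfur. Also relevant is a step that the two limits leave unreadable from compound 1 to compound 3 with phenylsulfonyl in place of (phenoxymethyl)carbonyl. Neither size can be read, and compound 1, compound 2 and compound 3 all share the limit of > 95% in this assay, at which 3 of the 3 values shown sit, as their result.

The expected result is a step that the limit leaves unreadable from compound 3 to compound 4 in this assay with no shift beyond the usual scatter in either direction. Compound 4 is estimated at 96% within an expected range from 86% to 100%.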

Compound 4, percent of the compound remaining: > 95%
Compound 4: a limit, no number; the forecaster's own chance of this, stated with the estimate: 70%; the middle value is on the limit's open side.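

In this assay compound 4 gives > 95% as a limit of the assay and not a number. Going by these compounds alone, no step among compound 1, compound 2, compound 3 and compound 4 can be read, as all four share one limit: the limit of > 95% in this assay, at which 4 of the 4 values shown sit. On these data alone, whether these four compounds truly differ in stability stays open.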